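This account rests on a few compounds, and the source may have more. Where it says the series, first, only, none or still open, it means among the compounds named here.

Measured compounds in an in vitro ADME assay on microsomes from liver (Homo sapiens) for pharmacokinetics, read by LC-MS, with a stated time of 10 min, tested at 1 uM; on this read-out higher numbers stand for fast clearance and lower numbers for slow clearance:
- compound 1 `COc1ccc(NC(=O)[C@H]2CN(C)C[C@@H]2c2ccc(/C=C/C(=O)Nc3ccccc3N)cc2)cc1` gives 14 mL/min/kg
- compound 2 `Cc1cc(NC(=O)[C@H]2CN(C)C[C@@H]2c2ccc(/C=C/C(=O)Nc3ccccc3N)cc2)ccc1F` gives 15 mL/min/kg

Within the data shown here, compound 2 stands at the higher of the two numbers in this assay, but its only neighbour is compound 1, and the step of a 1.1-fold higher number from compound 1 to compound 2 (0.03 log units; within the scatter) lies within the scatter, so the two compounds cannot be told apart on this read-out.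

Compound 3 `CC(C)NC(=O)[C@H]1CN(C)C[C@@H]1c1ccc(/C=C/C(=O)Nc2ccccc2N)cc1` is not yet measured. It differs from compound 2 in one place: isopropyl in place of 4-fluoro-3-methylphenyl on an amide-type nitrogen. Among the measured compounds shown here, the one measured step, a 1.1-fold higher number from compound 1 to compound 2 (0.03 log units; within the scatter), exchanges one aryl group for another on the same amide-type nitrogen and shows no movement beyond the scatter. For the measured compounds named here, no measured step replaces an aryl group on that nitrogen with an alkyl group, so there is no direct precedent for the move to isopropyl; the only evidence is that the two aryl variants sit at the same level.

On that basis compound 3 is expected to stay close to compound 2, with the step of a 1.2-fold lower number from compound 2 to compound 3 (0.06 log units; within the scatter) expected to fall within the scatter, though the range is kept wide for the untested type of change. The estimate for compound 3 in this assay is 13 mL/min/kg, with a range from 6 mL/min/kg to 28 mL/min/kg.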

Compound 3, clearance: 8 mL/min/kg
The estimate for compound 3 lay 1.6-fold (0.21 log units) above the measured number, and the stated range covers the measured number.
By their numbers in this assay, from the lowest: compounds 3, 1 and 2 (each within the scatter of the next).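

With isopropyl on the amide-type nitrogen, this assay gives a 1.9-fold lower number from compound 2 to compound 3 (0.27 log units; within the scatter) and also a 1.8-fold lower number from compound 1 to compound 3 (0.24 log units; within the scatter). Among these compounds, the earlier pair exchanged only one aryl group for another, whereas these steps show that an alkyl group with no ring can replace either aryl group at this position without a shift beyond the scatter, so an aromatic ring on this nitrogen is not needed to keep the read-out at this level among the three compounds. No measurement at hand bears on what lies behind these numbers.

All three compounds therefore sit at one level on this read-out, which leaves open whether any group on this nitrogen can move the number beyond the scatter at all. A longer alkyl chain, a chain ending in an amine or a carboxylic acid, or a methyl group in place of the amide hydrogen would test that, and each would show whether the flat picture seen with 4-methoxyphenyl, 4-fluoro-3-methylphenyl and isopropyl extends further.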